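Hydrogen for Chloro on Compound 2: an Expected Paw-Edema Read-Out

The source may report more compounds than this note shows. Statements on the series, on what has been measured and on what is new or still open speak of the compounds shown alone.

Measured compounds:
compound 1 `O=C1CSC(c2ccccc2)N1n1c(CSc2nnc(-c3ccncc3)o2)nc2ccccc2c1=O` — 30.1%
compound 2 `O=C1CSC(c2ccc(Cl)cc2)N1n1c(CSc2nnc(-c3ccncc3)o2)nc2ccc(Br)cc2c1=O` — 25.2%

In a functional assay on the whole organism (strain Charles-Foster albino) for inhibition, with Rattus norvegicus as the target, read by paw edema, at a dose of 50 mg/kg by the oral route (a higher number here means more inhibition at the dose given (going by the name of the read-out), a lower number less inhibition), compound 2 gives the lowest of the two numbers, 25.2%. Its nearest neighbour is compound 1, whose value sits higher by a gap within the scatter, so the two cannot be put in order. Compound 3 `O=C1CSC(c2ccccc2)N1n1c(CSc2nnc(-c3ccncc3)o2)nc2ccc(Br)cc2c1=O` has not yet been measured. It differs from compound 2 by hydrogen in place of chloro on an aromatic carbon. Among the compounds with values here, no measured pair isolates this change, so only a modest step is expected from compound 2 to compound 3, a number 2.8 percentage points higher from compound 2 to compound 3 (within the scatter), in either direction and not beyond the scatter. Compound 3 is therefore expected to give 28%, with a range from 18% to 38%.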

Compound 3, a percentage reported as inhibition, in the whole organism at one dose (the size of the read-out at that dose, not a potency): 31.3%
For compound 3 the middle estimate is 3.3 percentage points below the measured one; the range from low to high includes it.
By their numbers in this assay, from the lowest: compounds 2, 1 and 3 (each within the scatter of the next).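

In this assay hydrogen in place of chloro gives a number 6.1 percentage points higher from compound 2 to compound 3 (within the scatter) and so the phenyl and 4-chlorophenyl compounds cannot be put in order at this position. Bromo in place of hydrogen on an aromatic carbon gives a number 1.2 percentage points higher from compound 1 to compound 3 (within the scatter) and this second change likewise separates no pair. Nothing measured here offers an explanation for either step.

On these data alone, whether an amine or a carboxylic acid at this same place on the phenyl group would move the read-out beyond the scatter remains open.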